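Nitrile to Oxadiazole: an Expected Solubility Step

The source may report more compounds than this note shows. Statements on the series, on what has been measured and on what is new or still open speak of the compounds shown alone.

Compound 1 `Cc1nc(C#N)c(N)c2c1C(=O)N(Cc1ccccc1)C2=O`: < 5000 nM
Compound 2 `CNC(=O)c1nc(C)c2c(c1N)C(=O)N(Cc1ccccc1)C2=O`: 41000 nM

In a physicochemical assay for solubility, using the shake flask method, in simulated intestinal fluid, measured as kinetic solubility, with a stated time of 2 h, at 25 degrees C, at pH 6.5 (a higher number here means a more soluble compound, a lower number a less soluble compound), compound 1 gives < 5000 nM, which is a limit of the assay and not a number (the limit of < 5000 nM in this assay, at which 1 of the 2 values shown sits). In this assay compound 2 gives 41000 nM. Within the data shown here, the only measured step, an at least 8.2-fold higher number from compound 1 to compound 2 (0.91 log units; beyond the scatter), bears on compound 3 `Cc1noc(-c2nc(C)c3c(c2N)C(=O)N(Cc2ccccc2)C3=O)n1`, which differs from compound 1 by 3-methyl-1,2,4-oxadiazol-5-yl in place of cyano on an aromatic carbon. Both changes remove the cyano, so a rise beyond the scatter is expected, though the step of an at least 1.8-fold higher number from compound 1 to compound 3 (0.25 log units; that floor lies within the scatter) is expected to be smaller than the measured one. Compound 3 is estimated at 9000 nM, within 2500 nM to 30000 nM.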

Compound 3, solubility: < 5000 nM
Compound 3: no number, only a limit (the forecaster's own chance of this, stated with the estimate: 35%); middle value at least 1.8-fold (0.25 log units) away from the limit.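

Methylcarbamoyl and 3-methyl-1,2,4-oxadiazol-5-yl on this aromatic carbon are not interchangeable in this assay: exchanging the first for the second gives an at least 8.2-fold lower number from compound 2 to compound 3 (0.91 log units; beyond the scatter). Losing the cyano therefore does not by itself bring the higher number seen for compound 2. The values of compound 1 and compound 3 are both limits of the assay, and the step between them cannot be read: the limit of < 5000 nM in this assay, at which 2 of the 3 values shown sit.

On these data alone, how far apart compound 1 and compound 3 truly lie stays open. So does what an amine or a carboxylic acid on this carbon would give.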